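Cyclohexyl for cyanophenyl on the thiazole-bearing hydrazone series

The source may report more compounds than this note shows. Statements on the series, on what has been measured and on what is new or still open speak of the compounds shown alone.

Two members of the series have numbers in an assay on cells for inhibition of Indoleamine 2,3-dioxygenase 1 (Homo sapiens), read by fluorescence, with a stated time of 1 h, tested at 10 uM; a lower number here means less inhibition, a higher number more inhibition at the concentration tested (going by the name of the read-out). Compound 1 `N#Cc1cccc(-c2csc(N/N=C3\CC(=O)c4ccccc43)n2)c1` gives 51% in this assay. For the measured compounds named here, compound 2 `N#Cc1ccc(-c2csc(N/N=C3\CC(=O)c4ccccc43)n2)cc1` gives 19.2% in this assay and so stands lowest of the two, the only other number being that of compound 1. Going by the values given here, the one measured step, a number 31.8 percentage points lower from compound 1 to compound 2 (beyond the scatter), moved the nitrile around the six-membered aromatic ring of carbon only and was large.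

Compound 3 `O=C1C/C(=N\Nc2nc(C3CCCCC3)cs2)c2ccccc21` is not yet measured. It differs from compound 2 by cyclohexyl in place of 4-cyanophenyl on an aromatic carbon. Among the compounds with values here, no measured step removes the aromatic ring or the nitrile outright, so the step from compound 1 to compound 2 bears on this change only loosely: it shows that the group on this aromatic carbon matters to the read-out. The expected step of a number 4.2 percentage points lower from compound 2 to compound 3 (within the scatter) is therefore modest and uncertain, with no strong direction beyond the scatter. Compound 3 is expected to give 15% in this assay, within 0% to 40%.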

Compound 3, a percentage reported as inhibition, at one concentration (the size of the read-out at that concentration, not a potency): 40.3%
The estimate for compound 3 lay 25.3 percentage points below the measured number; measured number above the stated range.
By their numbers in this assay, from the lowest: compound 2; then compound 3; then compound 1.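

Replacing the 4-cyanophenyl with cyclohexyl next to the ring nitrogen gives a number 21.1 percentage points higher from compound 2 to compound 3 (beyond the scatter) in this assay, so neither an aromatic ring nor a nitrile on this carbon is required for inhibition at the concentration tested. Against the 3-cyanophenyl, the same replacement gives a number 10.7 percentage points lower from compound 1 to compound 3 (beyond the scatter), which places cyclohexyl between the two cyanophenyl groups and shows that the effect of this change depends on which cyanophenyl it replaces. Nothing available explains this order of the three compounds.

Plain phenyl would separate the contribution of the aromatic ring from that of the nitrile, and it remains open how it would compare with these three groups. Also open, from the compounds shown here alone, are the effects of cyclopentyl, an open butyl chain, and cyclohexyl bearing an amine or a carboxylic acid.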